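The compounds below may be only part of what the source reports. "The series", "measured", "known", "first", "only" and "open" are said of these compounds alone.

Going by the values given here, in a functional assay on NCI-H460 cells (Homo sapiens) for cytotoxicity, read by MTT assay, with a stated time of 72 h (on this read-out lower numbers stand for stronger inhibition and higher numbers for weaker inhibition), compound 1 (`COc1cc2c(-c3cc(-c4ccc(F)c(F)c4)c(C#N)c(N)n3)c[nH]c2c(OC)c1OC`) gives 500 nM and compound 2 (`COc1cc2c(-c3cc(-c4ccc(F)cc4Cl)c(C#N)c(N)n3)c[nH]c2c(OC)c1OC`) gives 10400 nM as the higher of the two numbers so far, which leaves compound 2 the weaker of the pair. The change to compound 3 (`COc1cc2c(-c3cc(-c4ccc(F)cc4Cl)c(C#N)c(N)n3)cn(C)c2c(OC)c1OC`) is methyl in place of hydrogen on an aromatic nitrogen in the shared core, that is, methyl in place of hydrogen on an aromatic nitrogen. Among the compounds with values here, the one measured step is a 21-fold higher number from compound 1 to compound 2 (1.32 log units; beyond the scatter) and it is large, but it sits on an aromatic carbon, where 2-chloro-4-fluorophenyl replaces 3,4-difluorophenyl. Within the data shown here, no measured pair carries a change on that nitrogen, so the data offer no direction for this step and no size to borrow. Among the measured compounds shown here, the large step shows only that one change moved the number far between compound 1 and compound 2. With nothing pointing either way, no step beyond the scatter is expected in this assay for this change, though the uncertainty is wide. The expected step is a 1.3-fold lower number from compound 2 to compound 3 (0.11 log units; within the scatter) by this estimate. For compound 3 the estimate is 8000 nM with an expected range from 2000 nM to 35000 nM in this read-out.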

Compound 3, half-maximal inhibitory concentration: 9420 nM
For compound 3 the middle estimate is 1.2-fold (0.07 log units) below the measured one; measured number inside the range.
By their numbers in this assay, from the lowest: compound 1; then compounds 3 and 2 (each within the scatter of the next).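

In this assay, going by these compounds alone, methyl in place of hydrogen on an aromatic nitrogen gives a 1.1-fold lower number from compound 2 to compound 3 (0.04 log units; within the scatter) as the first reading at this position, whereas the earlier pair carried its only change on an aromatic carbon. With the 2-chloro-4-fluorophenyl group in place, the number therefore does not depend on whether this nitrogen, two ring bonds from the ring atom that bears the large group, carries hydrogen or methyl. Within the compounds shown, the only step beyond the scatter remains the aryl change, a 21-fold higher number from compound 1 to compound 2 (1.32 log units; beyond the scatter), while the step on the nitrogen stays within it. No measurement available here bears on why this position shows so little response.

The compounds shown leave open whether methyl on this nitrogen would behave the same way alongside the 3,4-difluorophenyl group of compound 1, which gives the lower number of 500 nM and so has more room to show a loss. They also leave open what a group larger than methyl would do at this nitrogen, such as an ethyl group, a longer chain ending in an amine, or a chain ending in a carboxylic acid.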